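The source may report more compounds than this note shows. Statements on the series, on what has been measured and on what is new or still open speak of the compounds shown alone.

Working notes on the enone series built on the shared core of compound 1 `Cn1cccc1C(=O)/C=C/c1ccc2c(c1)B(O)OC2`. In a toxicity assay on WI-38 cells (Homo sapiens) for cytotoxicity, read by MTT assay, with a stated time of 48 h (a lower number here means a stronger inhibitor, a higher number a weaker inhibitor), compound 1 gives > 100000 nM. That entry is a limit of the assay rather than a number: compound 1 sits at the limit of > 100000 nM in this assay, at which 1 of the 3 values shown sits. Compound 2 `O=C(/C=C/c1ccc2c(c1)B(O)OC2)c1ccc(Br)cc1` gives 36700 nM in this assay, and compound 3 `Nc1ccc(C(=O)/C=C/c2ccc3c(c2)B(O)OC3)cc1` gives 25400 nM.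

Two steps leave compound 1: an at least 2.7-fold lower number from compound 1 to compound 2 (0.43 log units; beyond the scatter) and an at least 3.9-fold lower number from compound 1 to compound 3 (0.59 log units; beyond the scatter). Between the two phenyl analogues the step is small: a 1.4-fold lower number from compound 2 to compound 3 (0.16 log units; within the scatter). Compound 3 therefore holds the lowest of the two numbers in this assay, with compound 2 nearest and within the scatter of it, while compound 1 stands only at a limit.

Compound 4 `Cc1cccc(C(=O)/C=C/c2ccc3c(c2)B(O)OC3)c1` is the next member. The change from compound 3 is 3-methylphenyl in place of 4-aminophenyl on a carbonyl carbon. The step that bears most directly is the exchange of one substituent on the aromatic ring, a 1.4-fold lower number from compound 2 to compound 3 (0.16 log units; within the scatter), which stayed within the scatter; the two larger steps from compound 1 both kept a phenyl on the carbonyl carbon and are retained in compound 4. A step within the scatter is therefore expected, a 1.3-fold higher number from compound 3 to compound 4 (0.10 log units; within the scatter), with no confident direction. Compound 4 is estimated at 32000 nM in this assay, expected between 12000 nM and 85000 nM.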

Compound 4, half-maximal inhibitory concentration: 16700 nM
Compound 4: the middle estimate sits 1.9-fold (0.28 log units) above what was measured; the range from low to high includes it.
By their numbers in this assay, from the lowest: compounds 4, 3 and 2 (each within the scatter of the next, the first and the last beyond it). At a limit, above all of these: compound 1.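

The exchange of 4-aminophenyl for 3-methylphenyl on the carbonyl carbon gives a 1.5-fold lower number from compound 3 to compound 4 (0.18 log units; within the scatter), so in this assay this pair shows no effect beyond the scatter when the hydrogen-bond donor and acceptor counted on the leaving group are absent from the entering one. Among the compounds shown here, replacing 4-bromophenyl with the same group gives a 2.2-fold lower number from compound 2 to compound 4 (0.34 log units; beyond the scatter), the first step beyond the scatter between two phenyl analogues, though it is modest and compound 3 lies within the scatter of both compound 2 and compound 4. The remaining step, an at least 5.9-fold lower number from compound 1 to compound 4 (0.77 log units; beyond the scatter), again favours a substituted phenyl over 1-methyl-1H-pyrrol-2-yl on the carbonyl carbon, but its true size stays open, as it starts from the limit of compound 1: the limit of > 100000 nM in this assay, at which 1 of the 4 values shown sits.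

In the step from compound 2 to compound 4, both the substituent and its place on the ring change, so the compounds shown cannot assign that step to either one. On these data alone, how an unsubstituted phenyl, or a ring bearing a methoxy group or a carboxylic acid, would stand also remains open.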